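This account rests on a few compounds, and the source may have more. Where it says the series, first, only, none or still open, it means among the compounds named here.

Working notes on the series. Among the compounds with values here, compound 1 `CCOC(=O)c1cn(Cc2ccccc2F)c2cc(-c3ccc(N)cc3)c(CN(C)Cc3ccccc3)n2c1=O` and compound 2 `CCC(CC)OC(=O)c1cn(Cc2ccccc2F)c2cc(-c3ccc(OC)cc3)c(CN(C)Cc3ccccc3)n2c1=O` share one core and differ in two places at once, so no single step links them. In an assay on HEK293 cells for binding affinity to Gonadotropin-releasing hormone receptor (Homo sapiens), read by radioligand binding (a higher number here means a weaker inhibitor, a lower number a stronger inhibitor), compound 1 gives 190 nM. In this assay compound 2 gives 62 nM, the lowest of the two numbers shown, and its distance to compound 1 lies beyond the scatter.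

Compound 3 `CCC(CC)OC(=O)c1cn(Cc2ccccc2F)c2cc(-c3ccc(N)cc3)c(CN(C)Cc3ccccc3)n2c1=O` has not yet been measured. It follows from compound 2 by amino in place of methoxy on an aromatic carbon, and so carries the same amino group that compound 1 bears, while keeping the pentan-3-yl ester of compound 2. Within the data shown here, no measured pair isolates this change, so its size is open; the higher number of compound 1 at 190 nM is the only hint that the amino end may sit at a weaker value. The expectation is a modest rise in the number, a 1.8-fold higher number from compound 2 to compound 3 (0.25 log units; within the scatter), which may still fall within the scatter. Compound 3 is estimated at 110 nM, within 40 nM to 300 nM.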

Compound 3, inhibition constant: 100 nM
Estimate against measurement, compound 3: 1.1-fold (0.04 log units) above, within the range that was stated.
By their numbers in this assay, from the lowest: compounds 2, 3 and 1 (each within the scatter of the next, the first and the last beyond it).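

Amino in place of methoxy on an aromatic carbon, para to a large group, can now be read as a single step (a 1.6-fold higher number from compound 2 to compound 3 (0.21 log units; within the scatter)) in the series, and in (this assay) this step does not separate the two groups. With the 4-aminophenyl held constant, pentan-3-yl in place of ethyl on an oxygen next to a carbonyl group also stays unresolved (a 1.9-fold lower number from compound 1 to compound 3 (0.28 log units; within the scatter)), even though compound 1 and compound 2, which differ in both places, lie beyond the scatter of each other. Nothing at hand bears on the origin of either step.

Open, on these data alone, is whether a hydroxyl, a carboxylic acid or a longer alkoxy chain at this aromatic carbon would move the number beyond the scatter. Also open, as far as these compounds go, is whether an amide in place of the ester, or a branched chain other than pentan-3-yl, would do so.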